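The source may hold more compounds than are shown below. What is called first, only, known or untested is meant among the compounds shown, and "the series" means these compounds.

Compound 2 `CN1CCC(c2c[nH]c3ccc(NC(=O)c4ccncc4)nc23)CC1` gives 420 nM in an assay for binding affinity to 5-hydroxytryptamine receptor 1D (Homo sapiens), read by radioligand binding (on this read-out lower numbers stand for stronger inhibition and higher numbers for weaker inhibition), while compound 1 `Cc1cccc(C(=O)Nc2ccc3[nH]cc(C4CCN(C)CC4)c3n2)c1` gives 490 nM in this assay. For the measured compounds named here, the only step between the two measured compounds, a 1.2-fold lower number from compound 1 to compound 2 (0.07 log units; within the scatter), shows that exchanging the group on the carbonyl carbon left the number essentially where it was, so compound 2 sits alongside compound 1 with no separation beyond the scatter. Compound 3 `CN1CCC(c2c[nH]c3ccc(NC(=O)Nc4ccc(F)cc4)nc23)CC1` differs from compound 2 by (4-fluorophenyl)amino in place of pyridin-4-yl on a carbonyl carbon. That single measured step is the only one that bears on this change, and it was small; it suggests that the group carried by the carbonyl carbon is tolerated across some variation, though a change that also brings a new hydrogen-bond donor into that position is not directly covered. Compound 3 is therefore expected to stay close to compound 2, the estimated step being a 1.2-fold lower number from compound 2 to compound 3 (0.08 log units; within the scatter). Compound 3 is estimated to give 350 nM in this assay, within a range from 100 nM to 1200 nM.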

Compound 3, inhibition constant: 3.8 nM
Compound 3: the middle estimate sits 92-fold (1.96 log units) above what was measured; measured number below the stated range.
By their numbers in this assay, from the lowest: compound 3; then compounds 2 and 1 (each within the scatter of the next).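

In this assay, the group on the carbonyl carbon proved far from indifferent: (4-fluorophenyl)amino gives a 110-fold lower number from compound 2 to compound 3 (2.04 log units; beyond the scatter) and a 130-fold lower number from compound 1 to compound 3 (2.11 log units; beyond the scatter), although the exchange of the two earlier groups had given only a 1.2-fold lower number from compound 1 to compound 2 (0.07 log units; within the scatter). The position therefore responds strongly to this change, which was not visible from the two earlier compounds. Nothing available explains the size of these steps.

The entering group differs from both earlier groups in its amino nitrogen and in its fluorine, and the compounds shown do not separate the two. Plain phenylamino, 4-fluorophenyl bonded directly to the carbonyl carbon, or an alkylamino group such as methylamino would each bear on which part of the group goes with the lower number, and how far the effect extends remains open.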